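Ethyl on the Saturated Ring Carbon of Compound 3

The source may report more compounds than this note shows. Statements on the series, on what has been measured and on what is new or still open speak of the compounds shown alone.

Compound 1 `CC[C@H]1c2cc(Cl)ccc2C(=O)N1c1cncc2c1CCC[C@H]2NC(C)=O` gives 97 nM in an assay on cells for inhibition of cytochrome P450 11B2, mitochondrial (Homo sapiens), read by HTRF; a higher number here means a weaker inhibitor, a lower number a stronger inhibitor.
Compound 2 `C[C@@H](NS(C)(=O)=O)c1cncc(N2C(=O)c3ccc(Cl)cc3C2(C)C)c1` gives 8 nM in this assay.
Compound 3 `CCC(=O)N[C@@H]1CCCc2c1cncc2N1Cc2cc(Cl)ccc2C1=O` gives 28 nM in this assay.

Among the three measured compounds, compound 3 stands second highest. Its nearest neighbour is compound 1, whose number is higher by a margin beyond the usual scatter; compound 2 lies the same margin below, also beyond the scatter.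

Compound 4 `CCC(=O)N[C@@H]1CCCc2c1cncc2N1C(=O)c2ccc(Cl)cc2[C@@H]1CC` has not yet been measured. It differs from compound 3 in one place: ethyl in place of hydrogen on a saturated ring carbon. Going by the values given here, no pair of measured compounds differs in this single place, so the size of this step cannot be read directly from the data. Compound 1 carries an ethyl at the matching saturated ring carbon and gives a higher number than compound 3, but it also differs in its amide, so the two changes cannot be separated. Compound 2, with two methyl groups at that carbon, gives the lowest number of the three.

Given this, the step from compound 3 to compound 4 is expected to be small, leaning toward a weaker inhibitor, a 1.4-fold higher number from compound 3 to compound 4 (0.15 log units; within the scatter). Compound 4 is estimated at 40 nM, within a range from 12 nM to 130 nM.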

Compound 4, half-maximal inhibitory concentration: 12 nM
Estimate against measurement, compound 4: 3.3-fold (0.52 log units) above, and the stated range covers the measured number.
By their numbers in this assay, from the lowest: compounds 2 and 4 (each within the scatter of the next); then compound 3; then compound 1.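

In this assay, ethyl in place of hydrogen on this saturated ring carbon, next to the ring nitrogen, gives a 2.3-fold lower number from compound 3 to compound 4 (0.37 log units; beyond the scatter), so the added group goes with a stronger inhibitor rather than a weaker one. With ethyl present on both sides, the amide can now be separated from the ring substituent: methyl in place of hydrogen on the saturated chain carbon bound to a carbonyl carbon gives an 8.1-fold lower number from compound 1 to compound 4 (0.91 log units; beyond the scatter), which places the high number of compound 1 with its amide and not with its ethyl. No measurement on hand explains why either change lowers the number.

On these data alone, the ethyl step is seen with only one amide, so it remains open whether it would hold with another, and whether a propyl or a cyclopropyl on this ring carbon would go further or reverse the gain. As far as these compounds go, the amide side is equally open, since a butanamide or a longer chain on the carbonyl carbon could show whether the trend seen from compound 1 to compound 4 continues.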